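The compounds below may be only part of what the source reports. "The series", "measured", "known", "first", "only" and "open" are said of these compounds alone.

In a functional assay on HeLa cells (Homo sapiens) for antiproliferative activity, read by sulforhodamine B assay (a higher number here means a weaker inhibitor of growth, a lower number a stronger inhibitor of growth), compound 1 `CCCC[C@@H]1O[C@H](COCc2ccccc2)[C@@H](OCc2ccccc2)[C@H](OCc2ccccc2)[C@H]1O` gives > 50000 nM, which is a limit of the assay and not a number. Within the data shown here, compound 2 `C=CC[C@@H]1O[C@H](COCc2ccccc2)[C@@H](OCc2ccccc2)[C@H](OCc2ccccc2)[C@H]1O` gives 26200 nM, the only true number in this assay so far. Still unmeasured is compound 3 `OCC[C@@H]1O[C@H](COCc2ccccc2)[C@@H](OCc2ccccc2)[C@H](OCc2ccccc2)[C@H]1O`, which differs from compound 2 by hydroxymethyl in place of vinyl on a saturated chain carbon bound to a saturated ring carbon. In words, this is hydroxymethyl in place of vinyl on a saturated chain carbon bound to a saturated ring carbon; cut one bond further out, it reads allyl to 2-hydroxyethyl. A single measured step bears on it, an at least 1.9-fold lower number from compound 1 to compound 2 (0.28 log units; that floor lies within the scatter), made at the same place in the structure. That step is only a floor and involved a different exchange, so it sets no firm size for the new one. With so little to go on, no clear direction can be assigned, and the working expectation is no change beyond the scatter. The expected step is a 1.1-fold higher number from compound 2 to compound 3 (0.06 log units; within the scatter), an estimate that allows for the result being reported only as a limit. Compound 3 is estimated at 30000 nM, with an expected range of 12000 nM to 50000 nM.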

Compound 3, concentration for 50% growth inhibition: 30200 nM
Estimate against measurement, compound 3: 1.0-fold (0.00 log units) below; the measured number falls inside the stated range.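

Working notes on the series: in this assay, the exchange at this place reads as a 1.2-fold higher number from compound 2 to compound 3 (0.06 log units; within the scatter), so a chain end with one hydrogen-bond donor and one hydrogen-bond acceptor cannot be told apart from a chain end with neither, and the double bond outside aromatic rings is not needed to give a true number in this assay. Compound 1 gives > 50000 nM, which is a limit of the assay and not a number. The comparison with the propyl compound reads as an at least 1.6-fold lower number from compound 1 to compound 3 (0.21 log units; that floor lies within the scatter), so, as with the vinyl compound, a real gap between the saturated propyl chain and the 2-hydroxyethyl chain remains unproved, and the reading stops at a floor: the limit of > 50000 nM in this assay, at which 1 of the 3 values shown sits.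

Still open, from the compounds shown here alone, is whether any group at this place moves the number beyond the scatter, as an amine, a carboxylic acid or a longer chain ending in hydroxy might or might not do. No step shown so far lies beyond the scatter, so the compounds at hand give no direction for this position.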